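A few compounds are considered here, and "the series" means these few. Any claim that something is new, unique, unknown or untested is made for them only; others in the source may bear on it.

Working notes on the series in an in vitro assay on cells for inhibition of Amine oxidase [flavin-containing] B (Homo sapiens), read by Amplex Red, with a stated time of 15 min; on this read-out higher numbers stand for weaker inhibition and lower numbers for stronger inhibition. Compound 1 `O=C(/C=C(O)/C=C/c1ccc([N+](=O)[O-])cc1)c1ccccc1O` gives 2670 nM, the highest of the three numbers recorded so far. Compound 3 `O=C(/C=C/C=C/c1ccc(Cl)cc1)c1cc(Cl)ccc1O` gives 1460 nM, a number that sits within the usual scatter of that of compound 1, so the two cannot be told apart. Compound 2 `O=C(/C=C/C=C/c1ccccc1)c1cc(Cl)ccc1O` gives 54.8 nM, well below both.

Compound 4 `O=C(/C=C(O)/C=C/c1ccccc1)c1ccccc1O` is not yet measured. It differs from compound 1 by hydrogen in place of nitro on an aromatic carbon. Going by the values given here, the one measured step that bears on this is the reverse kind of change: a 27-fold higher number from compound 2 to compound 3 (1.43 log units; beyond the scatter), where a substituent enters on the aromatic carbon of the six-membered ring that carries the chain. The change to compound 4 removes a substituent from the same kind of position, so by that precedent a lower number is expected, though the step from compound 2 to compound 3 concerns chloro, not nitro, and the core of compound 1 differs from that of compound 2 by the enol, so the size is uncertain. An estimated step of a 5.3-fold lower number from compound 1 to compound 4 (0.73 log units; beyond the scatter) in this assay is therefore expected, toward stronger inhibition. For compound 4 the expected value is 500 nM, with a range of 100 nM to 2500 nM.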

Compound 4, half-maximal inhibitory concentration: 1160 nM
Compound 4: middle estimate off by 2.3-fold (0.37 log units), on the low side; low and high end bracket the measured number.
By their numbers in this assay, from the lowest: compound 2; then compounds 4, 3 and 1 (each within the scatter of the next, the first and the last beyond it).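

In this assay, the nitro group para to a large group can be exchanged for hydrogen with a 2.3-fold lower number from compound 1 to compound 4 (0.36 log units; beyond the scatter), so on the core of compound 1 as well, the unsubstituted aromatic carbon gives the lower number and thus the stronger inhibition. Going by these compounds alone, this matches the direction of the only earlier step at this kind of position, a 27-fold higher number from compound 2 to compound 3 (1.43 log units; beyond the scatter), read in reverse, but that chloro step on a different core is much larger, and the two pairs are the only basis for this pattern, with neither going against it. No measurement at hand offers an explanation for the direction of either step or for the difference in their sizes.

The compounds shown leave open whether the difference in size between the two steps follows from the group, nitro against chloro, or from the core, since neither group appears on both cores. An amine or a methoxy group at the same place on the core of compound 1 would show whether the higher number extends to other substituents, and chloro on that core would allow a direct comparison with the nitro of compound 1.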